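This account rests on a few compounds, and the source may have more. Where it says the series, first, only, none or still open, it means among the compounds named here.

Compound 1 `Cc1ccc2c(c1C)CN(CCCN(C)C)CC2c1ccccc1` is one of a small set built on a shared core. In a functional assay on A2780 cells (Homo sapiens) for antiproliferative activity (on this read-out lower numbers stand for stronger inhibition and higher numbers for weaker inhibition), compound 1 gives 3240 nM, the highest of the two numbers recorded. Compound 2 `Cc1ccc2c(c1C)CN(CCCCN(C)C)CC2c1ccccc1` gives 1860 nM in this assay, and the step of a 1.7-fold lower number from compound 1 to compound 2 (0.24 log units; within the scatter) lies within the scatter, so the two compounds cannot be ranked against each other. Compound 3 `Cc1ccc2c(c1C)CN(S(C)(=O)=O)CC2c1ccccc1` carries a different group on the same ring nitrogen; in this assay its result is recorded as "not determined" (no result reported), so it offers no number.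

Compound 4 `Cc1ccc2c(c1C)CN(C(=O)N(C)C)CC2c1ccccc1` differs from compound 1 by dimethylcarbamoyl in place of 3-(dimethylamino)propyl on an amine nitrogen in a ring. Going by the values given here, only the step from compound 1 to compound 2 touches this part of the molecule, and it changed the chain without removing it, staying within the scatter. Among the compounds with values here, no measured step replaces the whole chain with dimethylcarbamoyl, so the expectation rests on that single small step and carries a wide range. For compound 4 the estimate in this assay is 5000 nM, with a range from 1500 nM to 20000 nM, a step of a 1.5-fold higher number from compound 1 to compound 4 (0.19 log units; within the scatter) that is expected but not shown to exceed the scatter.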

Compound 4, half-maximal inhibitory concentration: 1200 nM
The estimate for compound 4 lay 4.2-fold (0.62 log units) above the measured number, and the stated range ends above it.
By their numbers in this assay, from the lowest: compounds 4, 2 and 1 (each within the scatter of the next, the first and the last beyond it).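

In this assay, going by these compounds alone, dimethylcarbamoyl in place of 3-(dimethylamino)propyl on the amine nitrogen in the ring gives a 2.7-fold lower number from compound 1 to compound 4 (0.43 log units; beyond the scatter), the first step at this position to lie beyond the scatter, though a modest one. In place of 4-(dimethylamino)butyl, the same group gives a 1.6-fold lower number from compound 2 to compound 4 (0.19 log units; within the scatter), so that pair cannot be ranked, and among these compounds a chain ending in dimethylamino is not needed at this position for a number in this range. No measurement shown accounts for either step.

With compound 3 giving no number, the compounds shown do not tell how a sulfonyl group compares here. They also leave open whether a smaller acetyl group, or a urea with its nitrogen in a morpholine ring, would fall in the same range.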